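The source may hold more compounds than are shown below. What is called first, only, known or untested is meant among the compounds shown, and "the series" means these compounds.

Measured so far:
compound 1, `CCCCCCCCCCCCCCCCCC(=O)Nc1nnc(S[C@@H]2O[C@H](COC(C)=O)[C@H](OC(C)=O)[C@H](OC(C)=O)[C@H]2OC(C)=O)s1` — 31200 nM
compound 2, `CCCCCCCC/C=C\CCCCCCCC(=O)Nc1nnc(S[C@@H]2O[C@H](CO)[C@H](O)[C@H](O)[C@H]2O)s1` — "not active" (no number reported)

For the measured compounds named here, compound 1 holds the only number in a functional assay on DU-145 cells (Homo sapiens) for cytotoxicity, read by MTT assay, with a stated time of 24 h; a higher number here means a weaker inhibitor, a lower number a stronger inhibitor: in this assay compound 1 gives 31200 nM. In this assay compound 2 is reported as "not active" (no number reported), with no number attached; it differs from compound 1 in more than one place, so nothing is counted between the two. Compound 3, `CCCCCC(=O)Nc1nnc(S[C@@H]2O[C@H](COC(C)=O)[C@H](OC(C)=O)[C@H](OC(C)=O)[C@H]2OC(C)=O)s1`, has not been measured. It differs from compound 1 by hydrogen in place of dodecyl on a saturated chain carbon, five bonds along the chain from a carbonyl carbon. Going by the values given here, no step between measured compounds is available to set a size, so the expectation rests on compound 1 alone. The step is expected to be small, within the scatter or at most a modest loss, because compound 1 at 31200 nM already sits at weak potency and the shorter amide chain offers no basis for expecting a gain. Compound 3 is therefore expected near 40000 nM, range 12000 nM to 150000 nM. The expected step is a 1.3-fold higher number from compound 1 to compound 3 (0.11 log units; within the scatter).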

Compound 3, half-maximal inhibitory concentration: "not active" (no number reported)
For compound 3 the study gives words and no number, so the estimate cannot be set against anything.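

In this assay, for the compounds shown here, compound 3 is reported in words only, so no step from compound 1 at 31200 nM can be read. Nothing shown bears on a cause for this result. The compounds shown leave open how the amide chain relates to potency in this assay.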